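Iodo for ethynyl on a shared nucleoside core

This account rests on a few compounds, and the source may have more. Where it says the series, first, only, none or still open, it means among the compounds named here.

Measured so far:
compound 1, `C#Cc1cn([C@@H]2O[C@H](CO)[C@@H](O)[C@H]2O)c2ncnc(NC)c12`, 18500 nM
compound 2, `C#Cc1cn([C@@H]2O[C@H](CO)[C@@H](O)[C@H]2O)c2nc(C)nc(N)c12`, 12600 nM
compound 3, `Cc1nc(N)c2c(I)cn([C@@H]3O[C@H](CO)[C@@H](O)[C@H]3O)c2n1`, 3480 nM

All values come from a functional assay on CEM-DNR-bulk cells (Homo sapiens), read by MTT assay, with a stated time of 72 h; on this read-out higher numbers stand for weaker inhibition and lower numbers for stronger inhibition. Compound 1 and compound 2 are built from the same atoms joined differently; the difference between the two cores is not broken down here, and their numbers lie within the scatter of each other. Compound 3 is compound 2 with one change, (iodo in place of ethynyl on an aromatic carbon), and that change gave a 3.6-fold lower number from compound 2 to compound 3 (0.56 log units; beyond the scatter).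

Compound 4, `CNc1ncnc2c1c(I)cn2[C@@H]1O[C@H](CO)[C@@H](O)[C@H]1O`, has not been measured in this assay. It differs from compound 1 by iodo in place of ethynyl on an aromatic carbon, the same change, at a place described in the same words. Compound 1 starts from 18500 nM. Because of a 3.6-fold lower number from compound 2 to compound 3 (0.56 log units; beyond the scatter) on the related core, a step of similar size is expected here, roughly a 3.6-fold lower number from compound 1 to compound 4 (0.56 log units; beyond the scatter). This rests on a single earlier occurrence, so the range is kept wide.

Compound 4 is expected to give about 5100 nM in this assay, with the estimate spanning 2000 nM to 13000 nM.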

Compound 4, half-maximal inhibitory concentration: > 20000 nM
Compound 4 gave a limit, no number (the forecaster's own chance of this, stated with the estimate: 5%); middle value at least 3.9-fold (0.59 log units) from the limit.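

In this assay compound 4 gives > 20000 nM, a limit of the assay and not a number. Iodo in place of ethynyl gives an at least 1.0-fold higher number from compound 1 to compound 4 (0.03 log units; that floor lies within the scatter), so the lower number seen on the core of compound 2 does not recur on the core of compound 1, and the two steps differ: the same change on two cores in this assay, a 3.6-fold lower number (0.56 log units; beyond the scatter) from compound 2 to compound 3 and an at least 1.0-fold higher number (0.03 log units; that floor lies within the scatter) from compound 1 to compound 4, at least 3.9-fold (0.59 log units) apart, beyond the scatter of two such steps The change therefore does not carry over in size between these two cores, but two pairs give no rule for the series, the limit leaves the full size of the new step unknown, and the data do not show which difference between the cores matters.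

On these data alone, only ethynyl and iodo appear on that aromatic carbon, so it remains open whether the split between the cores extends to other groups there. A bromo or a nitrile group in the same place on both cores would show whether the split is particular to iodo.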